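Aryl swap on the chain: compound 1 to compound 4

A few compounds are considered here, and "the series" means these few. Any claim that something is new, unique, unknown or untested is made for them only; others in the source may bear on it.

Compound 1 `COc1ccc(C(=O)/C=C/c2ccc(F)cc2)c2c1C=CC(C)(C)O2` is characterised in a functional assay on SK-OV-3 cells (Homo sapiens) for antiproliferative activity, read by MTT assay, with a stated time of 24 h; a lower number here means a stronger inhibitor, a higher number a weaker inhibitor. In this assay compound 1 reaches only a limit, > 10000 nM. Compound 2 `COc1ccc(C(=O)/C=C/c2cccc([N+](=O)[O-])c2)c2c1C=CC(C)(C)O2` gives 9720 nM in this assay. Compound 3 `COc1ccccc1/C=C/C(=O)c1ccc(OC)c2c1OC(C)(C)C=C2` likewise reaches only a limit in this assay, > 10000 nM. Compound 1 thus stands at the limit of > 10000 nM in this assay, at which 2 of the 3 values shown sit, and its place within the series cannot be fixed more closely. The step of an at least 1.0-fold lower number from compound 1 to compound 2 (0.01 log units; that floor lies within the scatter) has a floor within the scatter, the step that the two limits leave unreadable from compound 1 to compound 3 cannot be read, and the step of an at least 1.0-fold higher number from compound 2 to compound 3 (0.01 log units; that floor lies within the scatter) again shows only a floor within the scatter.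

Compound 4 `COc1ccc(C(=O)/C=C/c2cccc(O)c2)c2c1C=CC(C)(C)O2` differs from compound 1 in one place: 3-hydroxyphenyl in place of 4-fluorophenyl on a double-bonded chain carbon bound to a double-bonded chain carbon. The measured steps that bear on this change are the two other aryl swaps at the same place, starting from compound 1, and neither yields a readable size beyond the scatter. No step beyond the scatter is therefore expected in this assay. Compound 4 is expected to give about 12000 nM, with a range of 5000 nM to 30000 nM. The estimated step that the limit leaves unreadable from compound 1 to compound 4 is expected to stay within the scatter.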

Compound 4, half-maximal inhibitory concentration: > 10000 nM
Compound 4: no number, only a limit; the forecaster's own chance of this, stated with the estimate: 60%; the middle value does not contradict the limit.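

In this assay compound 4 reaches only a limit, and the series gathers at that limit: the limit of > 10000 nM in this assay, at which 3 of the 4 values shown sit. A group with a hydrogen-bond donor, 3-hydroxyphenyl, therefore yields no measurable number at this place on a double-bonded chain carbon bound to a double-bonded chain carbon, just as 4-fluorophenyl and 2-methoxyphenyl yield none; the steps to compound 4 from compound 1 and from compound 3 cannot be read. Hydroxy in place of nitro on an aromatic carbon gives an at least 1.0-fold higher number from compound 2 to compound 4 (0.01 log units; that floor lies within the scatter), so only a floor is known for that change.

Going by these compounds, how far the compounds at the limit differ from one another remains open. On these data alone, it is also open whether an amine or a carboxylic acid on the aryl group at this place would give a number clearly below the limit.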